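Methyl in place of chloro: compound 2 to compound 4

A few compounds are considered here, and "the series" means these few. Any claim that something is new, unique, unknown or untested is made for them only; others in the source may bear on it.

Measured in a functional assay on cells (Cancer cell lines, Homo sapiens) for inhibition; a higher number here means a weaker inhibitor of growth, a lower number a stronger inhibitor of growth:
- compound 1 `Nc1ccc(-c2nc3cc(F)ccc3s2)cc1`: 11500 nM
- compound 2 `Nc1ccc(-c2nc3ccc(F)cc3s2)cc1Cl`: < 10 nM
- compound 3 `Cc1cc(-c2nc3cccc(F)c3s2)ccc1N`: 40 nM

Compound 2 stands at a limit of the assay, < 10 nM, and not at a number. This is the limit of < 10 nM in this assay, at which 1 of the 3 values shown sits.

Compound 4 `Cc1cc(-c2nc3ccc(F)cc3s2)ccc1N` follows from compound 2 by one change, methyl in place of chloro on an aromatic carbon, ortho to an amino group.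

For the measured compounds named here, no measured pair isolates this change. Going by the values given here, compound 3, the only measured compound carrying methyl, gives 40 nM. A small step toward weaker growth inhibition, or none beyond the scatter, is expected in this assay. The estimated change is a number no lower from compound 2 to compound 4 (the limit leaves the size open). For compound 4 the expected value is 10 nM, with an estimated range of 1 nM to 60 nM.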

Compound 4, concentration for 50% growth inhibition: < 10 nM
Compound 4 gave a limit, no number; the forecaster's own chance of this, stated with the estimate: 45%; the middle value sits exactly at the limit.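

Compound 2 and compound 4 both stand at a limit and not at a number, so no step can be read between them: the limit of < 10 nM in this assay, at which 2 of the 4 values shown sit.

On these data alone, whether methyl and chloro on this aromatic carbon differ at all in this assay, and by how much, stays open.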